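A few compounds are considered here, and "the series" means these few. Any claim that something is new, unique, unknown or untested is made for them only; others in the source may bear on it.

Of the compounds shown here, three sharing one core have been measured in a functional assay on MGC-803 cells (Homo sapiens) for inhibition, read by MTT assay, with a stated time of 72 h; a lower number here means a stronger inhibitor, a higher number a weaker inhibitor. Compound 1 `C=CC(=O)Nc1cccc(NC(=O)CSc2nc(Nc3ccccc3)c3ccccc3n2)c1` gives 7310 nM and stands lowest of the two plain numbers. Compound 3 `O=C(CSc1nc(Nc2ccccc2)c2ccccc2n1)Nc1ccc(F)c(Cl)c1` gives 20900 nM. Compound 2 `CCc1ccc(NC(=O)CSc2nc(Nc3ccccc3)c3ccccc3n2)cc1` reaches only a limit, > 50000 nM, which is the edge of what this assay reports rather than a number (the limit of > 50000 nM in this assay, at which 1 of the 3 values shown sits). Every measured step changes the group on the amide-type nitrogen: a 2.9-fold higher number from compound 1 to compound 3 (0.46 log units; beyond the scatter), an at least 6.8-fold higher number from compound 1 to compound 2 (0.83 log units; beyond the scatter), and an at least 2.3-fold lower number from compound 2 to compound 3 (0.37 log units; beyond the scatter).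

Compound 4 `C=CC(=O)Nc1cccc(NC(=O)CSc2nc(Nc3cccc(Br)c3)c3ccccc3n2)c1` differs from compound 1 in another part of the molecule: bromo in place of hydrogen on an aromatic carbon, the bromo sitting on an aromatic carbon of a six-membered aromatic ring of carbon only, meta to a large group, turning the anilino into (3-bromophenyl)amino. Within the data shown here, none of the measured steps touches this part of the structure; they give no direct guide to the size or direction of the new step. With no step beyond the scatter to point to, the expectation is a change in this assay no larger than the usual scatter, a 1.3-fold lower number from compound 1 to compound 4 (0.12 log units; within the scatter). Compound 4 is therefore estimated at 5500 nM, with a range from 1800 nM to 17000 nM.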

Compound 4, half-maximal inhibitory concentration: 11900 nM
Beside the measured number, compound 4's estimate is 2.2-fold (0.34 log units) below it, within the range that was stated.
By their numbers in this assay, from the lowest: compounds 1, 4 and 3 (each within the scatter of the next, the first and the last beyond it). At a limit, above all of these: compound 2.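

Among these compounds, this is the first change made away from the amide-type nitrogen, and in this assay adding bromo to an aromatic carbon of the anilino group gives a 1.6-fold higher number from compound 1 to compound 4 (0.21 log units; within the scatter). Among the compounds shown here, compounds 1 and 4 therefore cannot be ranked, and this position accepts a bromo in place of hydrogen without a change that can be told from repeat-measurement scatter, whereas each of the earlier steps on the amide-type nitrogen went beyond that scatter. Nothing in the data shown accounts for the size of this step.

The compounds shown leave open whether a different group at this place, such as an amine or a carboxylic acid, would move the number beyond the scatter, and whether bromo on another carbon of that ring would behave as it does here. They also leave open whether the (3-bromophenyl)amino group would have the same small effect alongside the 3-chloro-4-fluorophenyl group of compound 3 or the 4-ethylphenyl group of compound 2 on the amide-type nitrogen.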